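Bromophenyl for methoxyphenyl on the ketone in two cores

The source may report more compounds than this note shows. Statements on the series, on what has been measured and on what is new or still open speak of the compounds shown alone.

Compound 1 `COC(=O)C1=C(N)Oc2c(OC)cc(Br)cc2C1CC(=O)c1cccc(OC)c1` gives 94.9% in a functional assay on MCF7 cells (Homo sapiens) for antiproliferative activity, read by sulforhodamine B assay, with a stated time of 72 h, tested at 30 uM; on this read-out lower numbers stand for a stronger effect and higher numbers for a weaker effect at the one concentration tested. Compound 2 `COC(=O)C1=C(N)Oc2c(OC)cc(Br)cc2C1CC(=O)c1ccc(Br)cc1` gives 31.9% in this assay; the change 4-bromophenyl in place of 3-methoxyphenyl on a carbonyl carbon made the step of a number 63 percentage points lower from compound 1 to compound 2 (beyond the scatter). Compound 3 `COc1cccc(C(=O)CC2C(C#N)=C(N)Oc3ccc(Br)cc32)c1` gives 34.4% in this assay; its value and that of compound 2 lie within the scatter of each other. The difference between the core of compound 3 and the core of compound 1 is not broken down here. Compound 4 `N#CC1=C(N)Oc2ccc(Br)cc2C1CC(=O)c1ccc(Br)cc1` carries the same change on the core of compound 3, (4-bromophenyl in place of 3-methoxyphenyl on a carbonyl carbon), and is not yet measured in this assay. A step the size of the earlier one is not expected from compound 3 to compound 4, because compound 3 already stands at 34.4% and the read-out cannot fall far; the expected step is a number 16.4 percentage points lower from compound 3 to compound 4 (beyond the scatter). Compound 4 is estimated at 18%, expected between 5% and 35%.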

Compound 4, a percentage reported as activity, at one concentration (the size of the read-out at that concentration, not a potency): 34.2%
Compound 4: the middle estimate sits 16.2 percentage points below what was measured, within the range that was stated.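

On the core of compound 3, the change to 4-bromophenyl in place of 3-methoxyphenyl on a carbonyl carbon gives a number 0.2 percentage points lower from compound 3 to compound 4 (within the scatter) in this assay. The step therefore does not carry over in size from one core to the other: the same change on two cores in this assay, a number 63 percentage points lower (beyond the scatter) from compound 1 to compound 2 and a number 0.2 percentage points lower (within the scatter) from compound 3 to compound 4, 62.8 percentage points apart, beyond the scatter of two such steps With one pair on each core, this does not show which of the differences between the cores separates the two steps, nor how the change would behave on any further core.

From the compounds shown here alone, whether the nitrile, the methyl ester or the extra methoxy on the core governs the step remains open. So does the read-out with a carboxylic acid in place of the methyl ester, or with an amine on the phenyl ring of the ketone.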